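Bromofuran replaces chlorofuran on the cyanoacrylamide side chain

The source may report more compounds than this note shows. Statements on the series, on what has been measured and on what is new or still open speak of the compounds shown alone.

Measured compounds:
Compound 1, `COc1ccc(CNC(=O)/C(C#N)=C/c2ccco2)cc1`: 24000 nM
Compound 2, `COc1ccc(CNC(=O)/C(C#N)=C/c2ccc(C)o2)cc1`: 60000 nM
Compound 3, `COc1ccc(CNC(=O)/C(C#N)=C/c2ccc(Cl)o2)cc1`: 9000 nM

Compound 3 stands lowest of the three numbers in a functional assay on A2780 cells (Homo sapiens) for inhibition, read by MTT assay, with a stated time of 72 h; a higher number here means a weaker inhibitor of growth, a lower number a stronger inhibitor of growth. Its nearest neighbour is compound 1, and the gap is a 2.7-fold lower number from compound 1 to compound 3 (0.43 log units; beyond the scatter), a change of chloro in place of hydrogen on an aromatic carbon. Compound 2 lies furthest away, the gap being a 6.7-fold lower number from compound 2 to compound 3 (0.82 log units; beyond the scatter), chloro in place of methyl on an aromatic carbon. The remaining measured step, a 2.5-fold higher number from compound 1 to compound 2 (0.40 log units; beyond the scatter), shows that methyl in place of hydrogen on the same aromatic carbon moved the number the other way.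

Compound 4, `COc1ccc(CNC(=O)/C(C#N)=C/c2cc(Br)co2)cc1`, has not yet been measured in this assay. It differs from compound 3 in one place: 4-bromofuran-2-yl in place of 5-chlorofuran-2-yl on a double-bonded chain carbon bound to a double-bonded chain carbon. The measured steps all concern a substituent change on a single aromatic carbon of the shared core; none of them concerns a bromine, and none concerns the ring position the bromine occupies in compound 4. For the measured compounds named here, only the step from compound 1 to compound 3 bears on a halogen at all, and it was modest. A bromine at a different position of the ring could repeat that gain, reverse it, or stay within the scatter; the data give no way to decide. Compound 4 is therefore expected to sit close to compound 3, with the step estimated as a 1.3-fold higher number from compound 3 to compound 4 (0.12 log units; within the scatter). The estimate for compound 4 in this assay is 12000 nM, within a range from 4000 nM to 40000 nM.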

Compound 4, concentration for 50% growth inhibition: 28000 nM
Beside the measured number, compound 4's estimate is 2.3-fold (0.37 log units) below it; measured number inside the range.
By their numbers in this assay, from the lowest: compound 3; then compounds 1 and 4 (each within the scatter of the next); then compound 2.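

In this assay the gain that chloro gave does not extend to every halogen on the furan: 4-bromofuran-2-yl in place of 5-chlorofuran-2-yl gives a 3.1-fold higher number from compound 3 to compound 4 (0.49 log units; beyond the scatter) and gives that gain back. Bromo in place of hydrogen gives only a 1.2-fold higher number from compound 1 to compound 4 (0.07 log units; within the scatter) and so brings no gain of its own at this ring position. The bromo group still reads better than the methyl group, with a 2.1-fold lower number from compound 2 to compound 4 (0.33 log units; beyond the scatter) on exchanging 5-methylfuran-2-yl for 4-bromofuran-2-yl, and nothing at hand gives a reason for any of these steps.

The change from chloro to bromo alters both the halogen and the aromatic carbon that carries it, and the compounds shown leave open which of the two accounts for the loss. They also leave open how a fluoro, a nitrile or a methoxy group on the furan, or a longer chain in place of the methyl, would read in this assay against these compounds.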